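This account rests on a few compounds, and the source may have more. Where it says the series, first, only, none or still open, it means among the compounds named here.

Of the compounds shown here, two from this series have so far been tested in a functional assay on A549 cells (Homo sapiens) for cytotoxicity, read by sulforhodamine B assay; on this read-out lower numbers stand for an effect already at smaller amounts and higher numbers for an effect only at larger amounts of compound. Compound 1 `C=C[C@@](C)(CC[C@H]1C(C)=CC[C@H]2C(C)(C)CCC[C@]12C)O[C@@H]1O[C@@H](C)[C@@H](OC(C)=O)[C@H](O)[C@H]1O` gives 3.2 ug/mL in this assay. Compound 2 `C=C[C@@](C)(CC[C@H]1C(C)=CC[C@H]2C(C)(C)CCC[C@]12C)O[C@@H]1O[C@H](C)[C@H](O)[C@H](O)[C@H]1O` gives 3.5 ug/mL in this assay, and this number lies within the usual scatter of the number for compound 1, so on the figures at hand the two compounds cannot be told apart. The step under consideration leads from compound 2 to compound 3 `C=C[C@@](C)(CC[C@H]1C(C)=CC[C@H]2C(C)(C)CCC[C@]12C)O[C@@H]1O[C@H](C)[C@H](OC(C)=O)[C@H](O)[C@H]1O`, which has not yet been measured. The change between them is acetyl in place of hydrogen on an oxygen on a saturated carbon. Going by the values given here, no step between two measured compounds is available that isolates this change, so its effect is unknown. Because compound 1 gives 3.2 ug/mL and compound 2 gives 3.5 ug/mL, both close to each other, the expected step of a 1.1-fold lower number from compound 2 to compound 3 (0.03 log units; within the scatter) is none beyond the scatter. Compound 3 is therefore estimated at 3.3 ug/mL, with a range from 1.5 ug/mL to 7.5 ug/mL.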

Compound 3, concentration for half-maximal effect: 3.9 ug/mL
Compound 3: middle estimate off by 1.2-fold (0.07 log units), on the low side, within the range that was stated.
By their numbers in this assay, from the lowest: compounds 1, 2 and 3 (each within the scatter of the next).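

In this assay, going by these compounds alone, acetyl in place of hydrogen on this oxygen gives a 1.1-fold higher number from compound 2 to compound 3 (0.05 log units; within the scatter), so the first isolated look at the hydroxy to acetoxy exchange at this position shows no difference that can be told from the scatter. Compound 1 and compound 3 both carry the acetoxy group, and the read-out does not separate them either, with a 1.2-fold higher number from compound 1 to compound 3 (0.09 log units; within the scatter). This second step therefore speaks to configuration and not to the group, as the following shows: the fact that compounds 1 and 3 differ only in the configuration as drawn

Going by these compounds, the two stereocentres differ together in that pair, so what each one does alone remains open. On these data alone, it also remains open whether a longer acyl chain such as hexanoyl, a benzoyl group or a methyl ether on this oxygen would stay within the scatter as acetyl does.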